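Branched ester tail in place of the linear chain

This account rests on a few compounds, and the source may have more. Where it says the series, first, only, none or still open, it means among the compounds named here.

In a functional assay on HL-60 cells (Homo sapiens) for inhibition, read by MTT assay, with a stated time of 48 h (on this read-out lower numbers stand for stronger inhibition and higher numbers for weaker inhibition), compound 2 `CCCC(=O)OCCCCOC(=O)c1ccc(C(=O)Nc2ccc3c(c2)C(C)(C)CCC3(C)C)cc1` gives 7320 nM, the lowest of the two numbers in hand; compound 1 `Cc1cc2c(cc1C(=O)c1ccc(C(=O)OCCCCOC(=O)c3ccc(C(=O)Nc4ccc5c(c4)C(C)(C)CCC5(C)C)cc3)cc1)C(C)(C)CCC2(C)C` gives 24700 nM, a gap that lies beyond the scatter. Compound 3 `CCCC(CCC)C(=O)OCCCOC(=O)c1ccc(C(=O)Nc2ccc3c(c2)C(C)(C)CCC3(C)C)cc1` differs from compound 2 by ((1-propylbutyl)carbonyl)oxy in place of ((propylcarbonyl)oxy)methyl on a saturated chain carbon, three bonds along the chain from an oxygen next to a carbonyl group. Among the compounds with values here, no measured pair maps onto this change, so nothing in hand calibrates it; the step expected in this assay is a 1.1-fold higher number from compound 2 to compound 3 (0.04 log units; within the scatter), read as no change beyond the scatter in either direction. Compound 3 is accordingly estimated at 8000 nM, with a range from 2500 nM to 25000 nM.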

Compound 3, half-maximal inhibitory concentration: 835000 nM
Beside the measured number, compound 3's estimate is 100-fold (2.02 log units) below it; the measured number lies above the stated range.
By their numbers in this assay, from the lowest: compound 2; then compound 1; then compound 3.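

In this assay this saturated chain carbon proves sensitive to the change: ((1-propylbutyl)carbonyl)oxy in place of ((propylcarbonyl)oxy)methyl brings a 110-fold higher number from compound 2 to compound 3 (2.06 log units; beyond the scatter) and thus a large loss of inhibition. Within the data shown here, no earlier step bore on this position, so this is the first reading of it. Nothing in hand accounts for the size of the step.

Among these compounds, the single step carries both the branched ester tail and the change in chain, so their shares stay unseparated. From the compounds shown here alone, how an amine, a carboxylic acid or a longer linear chain would read at this place remains open.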